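Trimming a Tertiary Alcohol to Hydroxymethyl on a Chemokine Antagonist

The compounds below may be only part of what the source reports. "The series", "measured", "known", "first", "only" and "open" are said of these compounds alone.

Compound 1 `C[C@@H]1CC(c2cnc3c(C#N)nn([C@H](C)c4ccc(Cl)cc4Cl)c3n2)=CC[C@@H]1N1CCC[C@H]1C(C)(C)O` was tested in a functional assay on cells for antagonist activity at C-C chemokine receptor type 4 (Homo sapiens), read by fluorescence and calcium flux, with stated times of 2.5 s and 45 s (on this read-out higher numbers stand for weaker inhibition and lower numbers for stronger inhibition), where compound 1 gives 384 nM. Among the three measured compounds it sits in the middle: compound 2 `C[C@@H](Nc1cncc(C2=CCN(C(=O)[C@H]3CCCCN3)CC2)n1)c1ccc(Cl)cc1Cl` gives 54 nM, a stronger inhibitor beyond the scatter, while compound 3 `CC(c1ccc(Cl)cc1Cl)n1ncc2ncc(N3CCC(N4CCCCC4)CC3)nc21` gives 2580 nM, a weaker one beyond the scatter. Compound 4 `C[C@@H]1CC(c2cnc3c(C#N)nn([C@H](C)c4ccc(Cl)cc4Cl)c3n2)=CC[C@@H]1N1CCC[C@H]1CO` differs from compound 1 in one place: hydroxymethyl in place of 1-hydroxy-1-methylethyl on a saturated ring carbon. For the measured compounds named here, no measured pair shows this change, so nothing in the data sets its size. Since the group that leaves is larger than the one that enters and each carries a hydrogen-bond donor and a hydrogen-bond acceptor, only a small step is expected a 1.4-fold higher number from compound 1 to compound 4 (0.16 log units; within the scatter), toward weaker inhibition if any. Compound 4 is therefore estimated at 550 nM, within 200 nM to 1600 nM.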

Compound 4, half-maximal inhibitory concentration: 40 nM
The estimate for compound 4 lay 14-fold (1.14 log units) above the measured number, outside the stated range (below it).
By their numbers in this assay, from the lowest: compounds 4 and 2 (each within the scatter of the next); then compound 1; then compound 3.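

In this assay the exchange of 1-hydroxy-1-methylethyl for hydroxymethyl on this saturated ring carbon gives a 9.6-fold lower number from compound 1 to compound 4 (0.98 log units; beyond the scatter) and so moves toward stronger inhibition. This position is therefore sensitive to the change, even though both groups carry the same count of hydrogen-bond donors and acceptors. Nothing available accounts for the size of this step.

The compounds shown leave open whether an aminomethyl or a carboxylic acid would hold this gain in place of the hydroxymethyl. They also leave open how a longer chain, such as 2-hydroxyethyl, would read here.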